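Swapping a benzyl for a fluorophenyl on the shared core

The source may report more compounds than this note shows. Statements on the series, on what has been measured and on what is new or still open speak of the compounds shown alone.

The measured compounds:
- compound 1, `COc1cccc(CNCCCNc2ccnc3cc(Cc4ccccc4)ccc23)c1O`, 23 10^-6 cm/s
- compound 2, `COc1ccc(F)cc1CNCCCNc1ccnc2cc(CC(C)C)ccc12`, 23 10^-6 cm/s
- compound 3, `COc1ccc(F)cc1CNCCCNc1ccnc2cc(Cc3ccccc3)ccc12`, 23 10^-6 cm/s

In an ADME assay for permeability, using PAMPA, with a stated time of 30 min, at pH 7.4 (on this read-out higher numbers stand for higher permeability and lower numbers for lower permeability), compound 1 gives 23 10^-6 cm/s, and it stands level with compounds 2 and 3, whose values are within the scatter of its own. Compound 4, `COc1cccc(CNCCCNc2ccnc3cc(-c4ccc(F)cc4)ccc23)c1O`, has not yet been measured. It differs from compound 1 in one place: 4-fluorophenyl in place of benzyl on an aromatic carbon.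

Within the data shown here, two measured steps bear on this. The step of no change at the digits printed from compound 1 to compound 3 (within the scatter) changes the group on the chain carbon bound to the amine nitrogen. The step of no change at the digits printed from compound 2 to compound 3 (within the scatter) changes the group on the saturated chain carbon bound to the aromatic carbon of the shared core, which is the region touched by the change to compound 4. Both steps stayed within the scatter. Among the measured compounds shown here, neither step replaces a benzyl with a 4-fluorophenyl, so no step matches the change exactly.

Given that every change so far left this assay unmoved, compound 4 is expected to stay level with compound 1, with an expected step of no change at the digits printed from compound 1 to compound 4 (within the scatter). The estimate for compound 4 is 23 10^-6 cm/s, expected to fall between 12 10^-6 cm/s and 40 10^-6 cm/s.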

Compound 4, apparent permeability: 237 10^-6 cm/s
Beside the measured number, compound 4's estimate is 10-fold (1.01 log units) below it; measured number above the stated range.
By their numbers in this assay, from the lowest: compounds 1, 2 and 3 (each within the scatter of the next); then compound 4.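

Unlike the earlier changes, which stayed within the scatter, this one shows that the group on this aromatic carbon of the shared core can strongly move the read-out in this assay: 4-fluorophenyl in place of benzyl gives a 10-fold higher number from compound 1 to compound 4 (1.01 log units; beyond the scatter). The two groups are alike in heavy-atom count, ring type and hydrogen-bond counts, yet the swap makes two changes at once, removing the saturated carbon that links the ring to the core and adding a fluorine. Nothing measured here explains the rise.

The compounds shown leave open which of those two changes carries the step, something plain phenyl on this carbon could help separate. Also open, from the compounds shown here alone, is how an amine or a carboxylic acid on the ring here would read, and whether the step holds with 5-fluoro-2-methoxyphenyl in place of 2-hydroxy-3-methoxyphenyl.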